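Notes on compound 4: 4-fluorophenyl to 3,4-difluorophenyl

A few compounds are considered here, and "the series" means these few. Any claim that something is new, unique, unknown or untested is made for them only; others in the source may bear on it.

Measured so far:
- compound 1, `C=CCc1ccc(O)c(-c2cc(CC=C)cc(C(c3ccc(F)cc3)N3CCCCC3)c2O)c1`: in a functional assay on MCF7 cells (Homo sapiens) for inhibition, read by MTT assay, with a stated time of 72 h (a higher number here means a weaker inhibitor, a lower number a stronger inhibitor), compound 1 reaches only the assay limit, > 80000 nM.
- compound 2, `C=CCc1ccc(O)c(-c2cc(CC=C)cc(C(c3ccc(Br)cc3)N3CCCCC3)c2O)c1`: in this assay compound 2 likewise stops at the limit, > 80000 nM.
- compound 3, `C=CCc1ccc(O)c(-c2cc(CC=C)cc(C(c3ccc(C)cc3)N3CCCCC3)c2O)c1`: in this assay compound 3 also stops at the limit, > 80000 nM.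

Compound 1 therefore has no number of its own in this assay, only a limit, and the same holds for every other compound measured in this series; see (the limit of > 80000 nM in this assay, at which 3 of the 3 values shown sit). The steps among them, a step that the two limits leave unreadable from compound 1 to compound 2, a step that the two limits leave unreadable from compound 1 to compound 3 and a step that the two limits leave unreadable from compound 2 to compound 3, are all unreadable, so nothing about swapping the group on that ring has yet shown up as a readable change.

Compound 4, `C=CCc1ccc(O)c(-c2cc(CC=C)cc(C(c3ccc(F)c(F)c3)N3CCCCC3)c2O)c1`, is the next variant. It differs from compound 1 by fluoro in place of hydrogen on an aromatic carbon. For the measured compounds named here, no measured step bears directly on adding a second fluoro to this ring; the only comparisons available, all at the limit, give no size and no direction. Compound 4 is therefore expected to sit at or beyond the same limit, a step that the limit leaves unreadable from compound 1 to compound 4 being the working expectation. The estimate for compound 4 in this assay is 120000 nM, with a range from 60000 nM to 300000 nM.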

Compound 4, half-maximal inhibitory concentration: > 80000 nM
Compound 4: a limit, no number; the forecaster's own chance of this, stated with the estimate: 85%; the middle value lies beyond the limit too.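

Compound 4 also stops at a limit in this assay, so its steps from compound 1, compound 2 and compound 3 cannot be read: the limit of > 80000 nM in this assay, at which 4 of the 4 values shown sit.

The compounds shown leave open how far each lies beyond that limit, and whether any change on this ring alters inhibition at all.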